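Swapping Nitro for Chloro on a Triazole-Linked Core

The compounds below may be only part of what the source reports. "The series", "measured", "known", "first", "only" and "open" are said of these compounds alone.

Compound 2 `O=C1C[C@H](OCc2cn(-c3ccc([N+](=O)[O-])cc3)nn2)[C@H]2CO[C@@H]1O2` is measured in a functional assay on MDA-MB-231 cells (Homo sapiens) for cytotoxicity, read by MTT assay, with a stated time of 48 h (on this read-out lower numbers stand for stronger inhibition and higher numbers for weaker inhibition), where compound 2 gives 24800 nM. For the measured compounds named here, that is the only plain number in this assay; the other entry is a limit. Compound 1 `O=C1C[C@H](OCc2cn(Cc3ccccc3)nn2)[C@H]2CO[C@@H]1O2` gives > 50000 nM, which is a limit of the assay and not a number, as stated by the limit of > 50000 nM in this assay, at which 1 of the 2 values shown sits. Going by the values given here, compound 1 and compound 2 differ in more than one place, so no single step between them is counted, and nothing beyond their two values can be drawn from the pair.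

Compound 3 `O=C1C[C@H](OCc2cn(-c3ccc(Cl)cc3)nn2)[C@H]2CO[C@@H]1O2` has not been measured. It differs from compound 2 by chloro in place of nitro on an aromatic carbon. Among the compounds with values here, no measured step of this kind exists here, so the size of the change is open; a step within the scatter, in either direction, is the plainest expectation. The estimate for compound 3 in this assay is 30000 nM, with a range from 10000 nM to 100000 nM. This estimate means an expected step from compound 2 to compound 3 of a 1.2-fold higher number from compound 2 to compound 3 (0.08 log units; within the scatter).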

Compound 3, half-maximal inhibitory concentration: 26100 nM
Compound 3: the middle estimate sits 1.1-fold (0.06 log units) above what was measured, within the range that was stated.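

In this assay, for the compounds shown here, chloro in place of nitro on an aromatic carbon, para to a large group, gives a 1.1-fold higher number from compound 2 to compound 3 (0.02 log units; within the scatter), so this position now has a measured step and the two groups cannot be told apart here. 4-Chlorophenyl in place of benzyl on an aromatic nitrogen gives an at least 1.9-fold lower number from compound 1 to compound 3 (0.28 log units; that floor lies within the scatter), the first comparison in this set that changes only one place at that nitrogen, though its floor does not separate the two compounds. The value of compound 1 is a limit of the assay and not a number: the limit of > 50000 nM in this assay, at which 1 of the 3 values shown sits.

Only nitro and chloro are shown on this aromatic carbon, so it remains open whether an amine or a carboxylic acid there would give a clearly different number. From the compounds shown here alone, the full size of the step from benzyl to 4-chlorophenyl also remains open.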